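A few compounds are considered here, and "the series" means these few. Any claim that something is new, unique, unknown or untested is made for them only; others in the source may bear on it.

Within the data shown here, in a functional assay on K562 cells (Homo sapiens) for antiproliferative activity, read by MTT assay, with a stated time of 48 h (on this read-out higher numbers stand for weaker inhibition of growth and lower numbers for stronger inhibition of growth), no compound measured so far gives a number. Compound 1 (`COc1ccc(N(C)c2ncnc3[nH]cnc23)cc1`) reports only a limit, > 100000 nM. Compound 2 (`COc1ccc(N(C)c2nc(Cl)nc3[nH]cnc23)cc1`) also stands at a limit, > 100000 nM. Compound 3 (`COc1ccc(N(C)c2ncnc3c2ncn3Cc2cc(OC)c(OC)c(OC)c2)cc1`) likewise reports only a limit, > 100000 nM. The evidence therefore amounts to the limit of > 100000 nM in this assay, at which 3 of the 3 values shown sit. Among the measured compounds shown here, the one measured step is a step that the two limits leave unreadable from compound 1 to compound 2, so it offers no size to carry forward. Compound 4 (`COc1ccc(Cn2cnc3c(N(C)c4ccc(OC)cc4)nc(Cl)nc32)cc1`) differs from compound 2 by 4-methoxybenzyl in place of hydrogen on an aromatic nitrogen. For the measured compounds named here, no measured compound combines the chloro with such a group. Only a step toward stronger inhibition could be read, and a modest one is expected, though the limit may well hold. The expected change is an at least 3.3-fold lower number from compound 2 to compound 4 (0.52 log units; beyond the scatter). The estimate for compound 4 is 30000 nM, expected to lie between 1000 nM and 100000 nM.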

Compound 4, concentration for 50% growth inhibition: > 100000 nM
Compound 4: no number, only a limit (the forecaster's own chance of this, stated with the estimate: 50%); middle value at least 3.3-fold (0.52 log units) from the limit.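

Compound 2 and compound 4 both stand at a limit in this assay, so the step between them cannot be read. The compounds shown leave open whether any change to the shared core gives a readable number: the limit of > 100000 nM in this assay, at which 4 of the 4 values shown sit.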